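Two Fluorines on the Phenyl Group of Compound 1

The source may report more compounds than this note shows. Statements on the series, on what has been measured and on what is new or still open speak of the compounds shown alone.

Compound 1 `O/N=C(\CCN1CCN(c2ccccn2)CC1)c1ccccc1` carries a plain phenyl group on the carbon with a double bond to nitrogen. In a functional assay on HEK293 cells with D(4) dopamine receptor (Homo sapiens) as the target, read by FLIPR (on this read-out higher numbers stand for larger maximal responses and lower numbers for smaller maximal responses), compound 1 gives 70%, the lowest of the three numbers measured, although both other compounds sit within the scatter of it. Compound 2 `O/N=C(\CCN1CCN(c2ccccn2)CC1)c1ccccc1Cl` gives 74% and compound 3 `O/N=C(\CCN1CCN(c2ccccn2)CC1)c1cc(F)cc(F)c1` gives 74%; the step of a number 4 percentage points higher from compound 1 to compound 2 (within the scatter) and the step of a number 4 percentage points higher from compound 1 to compound 3 (within the scatter) both stay within the scatter. Compound 4 `O/N=C(\CCN1CCN(c2ccccn2)CC1)c1ccc(F)cc1F` differs from compound 1 by 2,4-difluorophenyl in place of phenyl on a carbon with a double bond to nitrogen. The step of a number 4 percentage points higher from compound 1 to compound 3 (within the scatter) is the closest guide, since it also replaces phenyl with a difluorophenyl group, and it points to a change no larger than the scatter. Compound 4 is therefore expected to give 73%, between 63% and 83%, an estimated step of a number 3 percentage points higher from compound 1 to compound 4 (within the scatter).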

Compound 4, largest response reached (reported as efficacy), in percent of the reference or control that the assay uses: 78%
Compound 4: middle estimate off by 5 percentage points, on the low side; measured number inside the range.
By their numbers in this assay, from the lowest: compounds 1, 2, 3 and 4 (each within the scatter of the next).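

In this assay, the position on the carbon with a double bond to nitrogen takes a third substituted phenyl group with the response still inside the scatter, at a number 8 percentage points higher from compound 1 to compound 4 (within the scatter). Moving the two fluorines around the ring makes no readable difference, at a number 4 percentage points higher from compound 3 to compound 4 (within the scatter), and neither does replacing 2-chlorophenyl, at a number 4 percentage points higher from compound 2 to compound 4 (within the scatter). Nothing available here explains these numbers. The compounds shown leave open whether a different kind of group on the phenyl ring, such as an amine or a carboxylic acid, would move the response beyond the scatter.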